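Swapping a Thiophene Amide for a Chlorophenyl Ether

The compounds below may be only part of what the source reports. "The series", "measured", "known", "first", "only" and "open" are said of these compounds alone.

Compound 1 `CC(C)=CCC/C(C)=C/CC1Cc2c(OCCCNS(=O)(=O)c3ccc(Cl)cc3)cc(=O)n(CCCO)c2CC1(C)C` and compound 2 `CC(C)=CCC/C(C)=C/CC1Cc2c(OCCCNC(=O)c3cccs3)cc(=O)n(CCCO)c2CC1(C)C` share one core and differ only in the group on the chain amine. In a functional assay on PANC-1 cells (Homo sapiens) for inhibition, read by MTT assay, with a stated time of 24 h, tested at 10 uM (a lower number here means less inhibition, a higher number more inhibition at the concentration tested (going by the name of the read-out)), compound 1 gives 16.1%, and in this assay compound 2 gives 11.5%. The step of a number 4.6 percentage points lower from compound 1 to compound 2 (within the scatter) shows that the two measured numbers cannot be told apart. Within the data shown here, compound 2 thus holds the lower of the two numbers recorded so far, with compound 1 as its only neighbour, and the gap between them is within the scatter.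

Compound 3 `CC(C)=CCC/C(C)=C/CC1Cc2c(OCCCOc3ccc(Cl)cc3)cc(=O)n(CCCO)c2CC1(C)C` carries the change (4-chlorophenoxy in place of ((thiophen-2-yl)carbonyl)amino on a saturated chain carbon, three bonds along the chain from an oxygen on an aromatic ring). Among the measured compounds shown here, the only measured step, from compound 1 to compound 2, replaced one acyl or sulfonyl group on the same amine by another and moved the read-out by a number 4.6 percentage points lower from compound 1 to compound 2 (within the scatter), which is within the scatter. For the measured compounds named here, no measured pair removes the amine entirely or introduces an aryl ether at this position, so the data offer no step that speaks directly to the change. On that basis compound 3 is expected to show a step of a number 2.5 percentage points higher from compound 2 to compound 3 (within the scatter) in this assay, that is none beyond the scatter. Compound 3 is therefore estimated at 14%, within a range of 0% to 32%.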

Compound 3, a percentage reported as inhibition, at one concentration (the size of the read-out at that concentration, not a potency): 0%
Estimate against measurement, compound 3: 14 percentage points above; low and high end bracket the measured number.
By their numbers in this assay, from the lowest: compound 3; then compounds 2 and 1 (each within the scatter of the next).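

Among these compounds, compound 1 and compound 2 carry a sulfonyl and a carbonyl on the same chain amine and could not be told apart, so those compounds showed only that this one exchange left no readable difference. Replacing the whole ((thiophen-2-yl)carbonyl)amino group with 4-chlorophenoxy, which leaves no amine nitrogen on the chain, gives in this assay a step of a number 11.5 percentage points lower from compound 2 to compound 3 (beyond the scatter) and, measured against the sulfonyl compound, a step of a number 16.1 percentage points lower from compound 1 to compound 3 (beyond the scatter), so among these three compounds the aryl ether alone stands apart from the two compounds that keep the amine. Nothing available here accounts for this difference.

Compound 3 loses the amine nitrogen and its carbonyl or sulfonyl group in a single change, so the three compounds cannot show which of these parts the difference follows, and a 4-chloroanilino group on the same chain would separate them. Going by these compounds, whether the chlorine of the 4-chlorophenoxy group or the length of the 3-(4-chlorophenoxy)propyl chain plays any part also remains open, and a plain phenoxy group or a longer chain would address those two points.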